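A few compounds are considered here, and "the series" means these few. Any claim that something is new, unique, unknown or untested is made for them only; others in the source may bear on it.

In a functional assay on MCF7 cells (Homo sapiens) for inhibition, read by MTT assay, with a stated time of 72 h (on this read-out lower numbers stand for stronger inhibition and higher numbers for weaker inhibition), compound 1 `COc1cc(OC)c(OC)cc1/C=C/C(=O)c1ccc(O)cc1O` gives 33800 nM. Compound 2 `COc1cc(OC)c(OC)cc1/C=C/C(=O)c1cc(Cl)ccc1O` gives > 150000 nM, which is a limit and not a number. Compound 3 `COc1cc(OC)c(OC)cc1/C=C/C(=O)c1ccc(C)cc1` differs from compound 2 by one exchange on a carbonyl carbon: 4-methylphenyl in place of 5-chloro-2-hydroxyphenyl on a carbonyl carbon. Among the measured compounds shown here, only one measured step touches this place, an at least 4.4-fold higher number from compound 1 to compound 2 (0.64 log units; beyond the scatter), and it is beyond the scatter. That single step shows that an exchange here can move the read-out by a modest amount or more, but it does not fix the direction of this new change. Since compound 2 stands at the limit, any measurable result for compound 3 must lie on the lower side, and a second limit remains quite possible. In this assay, a modest step is therefore expected, an at least 1.6-fold lower number from compound 2 to compound 3 (0.22 log units; that floor lies within the scatter). The estimate for compound 3 is 90000 nM, with an expected range from 30000 nM to 250000 nM.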

Compound 3, half-maximal inhibitory concentration: 33000 nM
Beside the measured number, compound 3's estimate is 2.7-fold (0.44 log units) above it; measured number inside the range.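

In this assay, the exchange on the carbonyl carbon now has a direction: an at least 4.5-fold lower number from compound 2 to compound 3 (0.65 log units; beyond the scatter), so 4-methylphenyl gives a measurable number where 5-chloro-2-hydroxyphenyl did not. Compound 2 holds a limit and not a number, so the size of this step is only a floor: the limit of > 150000 nM in this assay, at which 1 of the 3 values shown sits.

The second step, a 1.0-fold lower number from compound 1 to compound 3 (0.01 log units; within the scatter), shows that a group with no hydrogen-bond donors reaches the same level as 2,4-dihydroxyphenyl at this place.

The compounds shown do not separate the chlorine of 5-chloro-2-hydroxyphenyl from its hydroxy group as the part tied to the limit of compound 2. Going by these compounds, whether a phenyl group carrying an amine or a carboxylic acid on this carbonyl carbon would stay at the level of compound 1 and compound 3 also remains open.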